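Swapping one side chain: what compound 3 may show

The source may hold more compounds than are shown below. What is called first, only, known or untested is meant among the compounds shown, and "the series" means these compounds.

In an ADME assay on L6 cells (Rattus norvegicus) for cytotoxicity, read by resazurin assay, with a stated time of 72 h (on this read-out higher numbers stand for weaker inhibition and lower numbers for stronger inhibition), compound 1 `CN1CCN(CC(=O)NC2CC3(N4CCCC4)CC(c4ccccc4)C2C(c2ccccc2)C3)CC1` gives 50200 nM and compound 2 `CN1CCN(CC(=O)N2CCC3(N4CCCC4)CC(c4ccccc4)C2C(c2ccccc2)C3)CC1` gives 69100 nM. Within the data shown here, these two values lie within the usual scatter of repeated measurements, so compound 1 stands level with the only other measured compound. Both numbers show only weak effects on these cells.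

The next compound, compound 3 `O=C(CN1CCCCC1)OC1CC2(N3CCCC3)CC(c3ccccc3)C1C(c1ccccc1)C2`, has (((piperidin-1-yl)methyl)carbonyl)oxy in place of (((4-methylpiperazin-1-yl)methyl)carbonyl)amino on a saturated ring carbon. Among the measured compounds shown here, no measured step shows what a swap of this kind does in this assay, so the expectation rests only on the level set by compound 1 at 50200 nM. A modest move towards a lower number is expected, an estimated 1.4-fold lower number from compound 1 to compound 3 (0.16 log units; within the scatter), and it may not clear the scatter. For compound 3 the estimated value is 35000 nM, with an expected range from 12000 nM to 90000 nM.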

Compound 3, half-maximal inhibitory concentration: 14200 nM
Estimate against measurement, compound 3: 2.5-fold (0.39 log units) above; measured number inside the range.
By their numbers in this assay, from the lowest: compound 3; then compounds 1 and 2 (each within the scatter of the next).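

In this assay, among these compounds, the change on this saturated ring carbon gives a 3.5-fold lower number from compound 1 to compound 3 (0.55 log units; beyond the scatter) and this is the only step so far that clears the scatter, so altering the side chain at this position can move the number. The swap changes two things at once: the amino link, with its hydrogen-bond donor, becomes an oxy link, and the 4-methylpiperazin-1-yl ring becomes a piperidin-1-yl ring. Nothing measured here gives a reason for the step.

Still open, going by these compounds, is which of those two changes carries the step, or whether both are needed. A morpholine ring, or a longer chain between the carbonyl and the ring, would show how far this side chain can be varied on the shared core.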